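From a Drawn Stereocentre to None: Compound 4 Expected

A few compounds are considered here, and "the series" means these few. Any claim that something is new, unique, unknown or untested is made for them only; others in the source may bear on it.

Three compounds were measured in an ADME assay on microsomes from liver (Mus musculus) for metabolic stability; a higher number here means faster removal of the compound, a lower number slower removal. Compound 1 `O=C(Cc1nn(C2CCNC2)c(=O)c2ccccc12)Nc1ccc(OC(F)(F)F)c(Cl)c1` gives 16300 mL/min/kg in this assay. Compound 3 `O=C(O)Cn1nc(Cc2cn3cc(OCC4CC4)c(Cl)cc3n2)c2ccccc2c1=O` is reported only as a limit in this assay, < 58.4 mL/min/kg. Compound 2 `C[C@@H](C(=O)O)c1nn(Cc2cn3cc(OCC4CC4)c(Cl)cc3n2)c2ccccc2c1=O` is likewise reported only as a limit in this assay, < 55 mL/min/kg. So compound 2 stands at one of the two limits among the numbers shown, (the limit of < 55 mL/min/kg in this assay, at which 1 of the 3 values shown sits), while compound 3 sits at the other, (the limit of < 58.4 mL/min/kg in this assay, at which 1 of the 3 values shown sits), and only compound 1 carries a full number. Among the measured compounds shown here, no step between two measured compounds is available, as no measured pair differs in a single place.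

Compound 4 `CC(C(=O)O)c1nn(Cc2cn3cc(OCC4CC4)c(Cl)cc3n2)c2ccccc2c1=O` is the compound still to be measured. Its relation to compound 2 is this: the two compounds have the same atoms and bonds; at least one stereo element is drawn with a configuration in one of them and without one in the other: 1 of 1 stereo elements differ; a stereocentre at a saturated chain carbon is drawn R in compound 2 and without a configuration in compound 4. The two share every atom and bond. The step from compound 2 to compound 4 is therefore expected to stay within the scatter, without a direction, a step that the limit leaves unreadable from compound 2 to compound 4. Compound 4 is expected at 40 mL/min/kg, within a range from 15 mL/min/kg to 90 mL/min/kg, most probably reported again as a limit.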

Compound 4, clearance: 80 mL/min/kg
The estimate for compound 4 lay 2.0-fold (0.30 log units) below the measured number; the range from low to high includes it.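

Among the compounds shown here, the change at this saturated chain carbon gives the first step that can be read in this assay, and it is an at least 1.4-fold higher number from compound 2 to compound 4 (0.16 log units; that floor lies within the scatter). That step is only a floor, as compound 2 is held by a limit and not by a number: the limit of < 55 mL/min/kg in this assay, at which 1 of the 4 values shown sits. No atom or bond changes here, so the step concerns only whether the stereocentre is drawn with a configuration: the fact that one of compounds 2 and 4 is drawn with a defined configuration and the other without, at the place where they differ.

The compounds shown leave open how large the true step is, and whether it goes beyond the scatter at all, as well as how a form drawn S at this carbon would read in this assay. They also leave open whether a methyl ester or a primary amide in place of the carboxylic acid on this chain would read differently.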